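This account rests on a few compounds, and the source may have more. Where it says the series, first, only, none or still open, it means among the compounds named here.

Compound 1 `CC(C)(C)OC(=O)N1CCC(c2nc(COc3ccc(/C=C4\CC(=O)NC4=O)cc3)cs2)CC1` has no result in a functional assay on cells for agonist activity at Glucose-dependent insulinotropic receptor (Homo sapiens), read by a luciferase reporter, with a stated time of 6 h; a higher number here means that more compound is needed for the effect, a lower number that less compound is needed: for compound 1 the entry is "not determined" (no result reported). Within the data shown here, compound 2 `CCc1cnc(N2CCC(c3nc(COc4ccc(/C=C5\CC(=O)NC5=O)cc4)cs3)CC2)nc1` gives 182 nM in this assay, and this is the only number in hand, so compound 2 is the sole reference point for what follows. Compound 3 `CCc1cnc(N2CCC(c3nc(COc4ccc(-n5cnnn5)cc4)cs3)CC2)nc1` differs from compound 2 in a single place: a group of 5 heavy atoms (1 carbon, 4 nitrogen; one five-membered aromatic ring with 4 hetero atoms) in place of a group of 8 heavy atoms (5 carbon, 1 nitrogen, 2 oxygen; one five-membered non-aromatic ring with 1 hetero atom), on an aromatic carbon. Among the measured compounds shown here, no step between measured compounds is available to guide the size of the change. The step of an 8.2-fold higher number from compound 2 to compound 3 (0.92 log units; beyond the scatter) is expected to run toward a higher value, beyond the usual scatter. Compound 3 is estimated at 1500 nM in this assay, with a likely range from 400 nM to 6000 nM.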

Compound 3, half-maximal effective concentration: 87 nM
Estimate against measurement, compound 3: 17-fold (1.24 log units) above, and the stated range ends above it.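

In this assay, the change at this aromatic carbon, para to a large group, gives a 2.1-fold lower number from compound 2 to compound 3 (0.32 log units; beyond the scatter) and so shows that the group that leaves is not needed for activity in this pair. The 1H-tetrazol-1-yl group that enters has no hydrogen-bond donor and a smaller heavy-atom count, yet the number falls. Nothing measured here speaks to the reason for this step. From the compounds shown here alone, what remains open is how a carboxylic acid, an amine or a simple amide would fare at this position. Among these compounds, with only this pair, no trend across groups can be drawn.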